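Diethylamino for dimethylamino on a chloro-benzimidazole core

The source may hold more compounds than are shown below. What is called first, only, known or untested is meant among the compounds shown, and "the series" means these compounds.

Three compounds in this set were tested in a functional assay on HeLa cells (Homo sapiens) for antiproliferative activity, read by MTT assay, with a stated time of 48 h; on this read-out higher numbers stand for weaker inhibition and lower numbers for stronger inhibition. Compound 1 `CN(C)CCCn1c(N)c(-c2nc3ccccc3n2C)c2nc(C#N)c(C#N)nc21` gives 4320 nM, compound 2 `CCN(CC)CCCn1c(N)c(-c2nc3ccccc3n2C)c2nc(C#N)c(C#N)nc21` gives 12400 nM, and compound 3 `CN(C)CCCn1c(N)c(-c2nc3cc(Cl)ccc3[nH]2)c2nc(C#N)c(C#N)nc21` gives 16500 nM. Compound 2 differs from compound 1 by diethylamino in place of dimethylamino on a saturated chain carbon, three bonds along the chain from an aromatic nitrogen, and that change made a 2.9-fold higher number from compound 1 to compound 2 (0.46 log units; beyond the scatter). Compound 3 differs from compound 1 by 5-chloro-1H-benzimidazol-2-yl in place of 1-methyl-1H-benzimidazol-2-yl on an aromatic carbon, with a 3.8-fold higher number from compound 1 to compound 3 (0.58 log units; beyond the scatter). The values of compound 2 and compound 3 lie within the scatter of each other, so nothing can be said about their order.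

Compound 4 `CCN(CC)CCCn1c(N)c(-c2nc3cc(Cl)ccc3[nH]2)c2nc(C#N)c(C#N)nc21` has not yet been measured in this assay. It differs from compound 3 by diethylamino in place of dimethylamino on a saturated chain carbon, three bonds along the chain from an aromatic nitrogen. This is the same change as the one from compound 1 to compound 2, made at the same place, and the only thing that differs is the core, as described above for the difference between compound 1 and compound 3. Within the data shown here, the one step available for this change is the rise from compound 1 to compound 2, and that is what the expectation for compound 4 rests on, with the reservation that the step has been seen only once and on a different core. In this assay compound 4 is therefore expected to show a modest rise, a 2.4-fold higher number from compound 3 to compound 4 (0.38 log units; beyond the scatter), because the same change gave a 2.9-fold higher number from compound 1 to compound 2 (0.46 log units; beyond the scatter). The estimated value for compound 4 in this assay is 40000 nM, with a plausible range from 15000 nM to 110000 nM.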

Compound 4, half-maximal inhibitory concentration: 24400 nM
Compound 4: the middle estimate sits 1.6-fold (0.21 log units) above what was measured; the measured number falls inside the stated range.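

In this assay, diethylamino in place of dimethylamino on the core of compound 3 gave a 1.5-fold higher number from compound 3 to compound 4 (0.17 log units; within the scatter), and 5-chloro-1H-benzimidazol-2-yl in place of 1-methyl-1H-benzimidazol-2-yl on the diethylamino side gave a 2.0-fold higher number from compound 2 to compound 4 (0.29 log units; within the scatter). The amine change is consistent in size across the two cores, although one pair per core cannot fix that size, and on the second core the step alone cannot be told from scatter: the same change on two cores in this assay, a 2.9-fold higher number (0.46 log units; beyond the scatter) from compound 1 to compound 2 and a 1.5-fold higher number (0.17 log units; within the scatter) from compound 3 to compound 4, 1.9-fold (0.29 log units) apart, within the scatter of two such steps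
Read the other way, the core change behaves alike with either amine, which shows only that these four compounds fit two changes that combine without a detectable interaction, not that the same would hold elsewhere in the series: the same change on two cores in this assay, a 3.8-fold higher number (0.58 log units; beyond the scatter) from compound 1 to compound 3 and a 2.0-fold higher number (0.29 log units; within the scatter) from compound 2 to compound 4, 1.9-fold (0.29 log units) apart, within the scatter of two such steps

The compounds shown leave open whether dipropylamino or a longer chain between the amine and the aromatic nitrogen would continue the same trend on either core. They also leave open how much of the core change belongs to the chloro group and how much to the methyl group, since the two differ together here, and a benzimidazol-2-yl group carrying only one of them would separate the two.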